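The source may hold more compounds than are shown below. What is called first, only, known or untested is meant among the compounds shown, and "the series" means these compounds.

Three compounds that share one core have been run in a functional assay on NCI-H23 cells (Homo sapiens) for cytotoxicity, read by sulforhodamine B assay, with a stated time of 72 h; a higher number here means a weaker inhibitor of growth, a lower number a stronger inhibitor of growth. Compound 1 `COc1ccc(NC(=O)C2CCc3ccccc3N2)cc1` gives 55700 nM. Compound 2 `O=C(Nc1ccccc1)C1CCc2ccccc2N1` gives 97100 nM. Compound 3 `O=C(Nc1cc(C(F)(F)F)cc(C(F)(F)F)c1)C1CCc2ccccc2N1C(=O)c1ccc(Cl)cc1` differs from compound 2 in several places at once; in this assay compound 3 gives 889 nM. Among these three numbers compound 2 stands highest; compound 1 lies nearest to it, and compound 3, with a far lower value, lies furthest away.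

Compound 4 `O=C(Nc1ccccc1O)C1CCc2ccccc2N1` has not yet been measured in this assay . It differs from compound 2 by hydroxy in place of hydrogen on an aromatic carbon, the hydroxy sitting on an aromatic carbon of a six-membered aromatic ring of carbon only, ortho to a large group. For the measured compounds named here, the only measured step that bears on this kind of change, a swap of a small group on that same aromatic ring, is a 1.7-fold higher number from compound 1 to compound 2 (0.24 log units; within the scatter), which stayed within the scatter. Compound 3 cannot guide the step, since its many changes cannot be separated. On this basis no step beyond the scatter is expected in this assay .

Compound 4 is therefore expected to give about 90000 nM. The range expected for compound 4 runs from 40000 nM to 200000 nM. This amounts to an expected step of a 1.1-fold lower number from compound 2 to compound 4 (0.03 log units; within the scatter).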

Compound 4, concentration for 50% growth inhibition: 2230 nM
For compound 4 the middle estimate is 40-fold (1.61 log units) above the measured one; the measured number lies below the stated range.
By their numbers in this assay, from the lowest: compound 3; then compound 4; then compounds 1 and 2 (each within the scatter of the next).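

In this assay, hydroxy in place of hydrogen on an aromatic carbon, ortho to a large group, gives a 44-fold lower number from compound 2 to compound 4 (1.64 log units; beyond the scatter), a large change from a single added heavy atom. The earlier step on the same six-membered aromatic ring of carbon only, a 1.7-fold higher number from compound 1 to compound 2 (0.24 log units; within the scatter), stayed within the scatter, so this ring does not respond to every small group in the same way: the outcome depends on the group, on its place or on both, and these two compounds cannot separate those possibilities. Nothing in the information available accounts for the size of this step.

The compounds shown leave open whether this drop in the number belongs to hydroxy itself or to this place more generally, which methoxy, fluorine or an amine on the same carbon, or hydroxy on another carbon of that ring, would help to settle. As far as these compounds go, it also remains open whether hydroxy would have a similar effect alongside the several other changes carried by compound 3.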